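A few compounds are considered here, and "the series" means these few. Any claim that something is new, unique, unknown or untested is made for them only; others in the source may bear on it.

Measured so far:
- compound 1, `NC(=O)c1cn(-c2ccc(O)cc2)c2cc(-c3ccncc3)ccc2c1=O`: 2000 nM
- compound 2, `NC(=O)c1cn(-c2ccc(O)cc2Cl)c2cc(-n3cccn3)ccc2c1=O`: 600 nM

In an assay on isolated protein for inhibition of Calpain-1 catalytic subunit (Homo sapiens) (on this read-out higher numbers stand for weaker inhibition and lower numbers for stronger inhibition), compound 1 gives 2000 nM, while compound 2 gives 600 nM. Compound 2 therefore holds the lower of the two numbers, and its gap to compound 1 lies beyond the scatter; the two compounds differ in more than one place, so nothing is isolated by that pair.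

Compound 3, `NC(=O)c1cn(-c2ccc(O)cc2Cl)c2cc(-c3ccoc3)ccc2c1=O`, is not yet measured. It differs from compound 2 in one place: furan-3-yl in place of 1H-pyrazol-1-yl on an aromatic carbon. Among the measured compounds shown here, no measured pair in this set isolates that change, so there is no basis for a step of known size in this assay. The working expectation is a step not beyond the scatter, with a slight lean toward weaker inhibition.

Compound 3 is expected to give 900 nM, with a range from 300 nM to 2700 nM. That estimate corresponds to an expected 1.5-fold higher number from compound 2 to compound 3 (0.18 log units; within the scatter).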

Compound 3, half-maximal inhibitory concentration: 2000 nM
Compound 3: the middle estimate sits 2.2-fold (0.35 log units) below what was measured, within the range that was stated.
By their numbers in this assay, from the lowest: compound 2; then compounds 1 and 3 (each within the scatter of the next).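

In this assay, among the compounds shown here, furan-3-yl in place of 1H-pyrazol-1-yl on the aromatic carbon gives a 3.3-fold higher number from compound 2 to compound 3 (0.52 log units; beyond the scatter) and provides the first single-place comparison. This position therefore distinguishes between two five-membered aromatic rings of 5 heavy atoms each, neither with a hydrogen-bond donor or a net charge. The groups differ in their hetero atoms, 2 nitrogen against 1 oxygen, and in their hydrogen-bond acceptors, 2 against 1, but no measurement bears on which difference accounts for the step.

The two compounds cannot separate the change of hetero atoms from the change in the attachment atom, from ring nitrogen to ring carbon. Open as well is how a 1H-imidazol-1-yl group, an amine or a carboxylic acid would read at this position.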